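Cytotoxicity limits in a cyclopropylidene nucleoside series

This account rests on a few compounds, and the source may have more. Where it says the series, first, only, none or still open, it means among the compounds named here.

Measured so far in an ADME assay on MOLT-3 cells (Homo sapiens) for cytotoxicity, with a stated time of 7 days; a lower number here means that less compound is tolerated, a higher number that more compound is tolerated:
- compound 1 `CNc1nc(N)nc2c1ncn2/C=C1/CC1(CO)CO`: compound 1 gives > 20000 nM, a limit of the assay and not a number.
- compound 2 `CN(C)c1nc(N)nc2c1ncn2/C=C1/CC1(CO)CO`: compound 2 gives "not determined" (no result reported), no result being reported for it.
- compound 3 `Nc1nc(OCc2ccccc2)c2ncn(/C=C3/CC3(CO)CO)c2n1`: compound 3 gives > 20000 nM, likewise a limit.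

Compound 1 therefore stands only at a limit, with no number for it. Within the data shown here, the single comparable step, a step that the two limits leave unreadable from compound 1 to compound 3, is unreadable for that reason; the limit of > 20000 nM in this assay, at which 2 of the 3 values shown sit, is the whole evidence.

Compound 4 `CCCSc1nc(N)nc2c1ncn2/C=C1/CC1(CO)CO` is reached from compound 1 by propylsulfanyl in place of methylamino on an aromatic carbon. Among the measured compounds shown here, no measured step reads on this change. The expectation for compound 4 is that this assay again reports a limit, so that a step that the limit leaves unreadable from compound 1 to compound 4 is expected to lie within the scatter. Compound 4 is estimated at 25000 nM, range 10000 nM to 60000 nM.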

Compound 4, half-maximal cytotoxic concentration: > 20000 nM
Compound 4: only a limit was reported (the forecaster's own chance of this, stated with the estimate: 70%); the middle value does not contradict the limit.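

Compound 4, like compound 1 and compound 3, gives only a limit in this assay, so no step among these compounds can be read: the limit of > 20000 nM in this assay, at which 3 of the 4 values shown sit.

The compounds shown leave open whether any group at this place on the shared core gives a readable cytotoxic concentration.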